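The source may hold more compounds than are shown below. What is called first, only, known or untested is meant among the compounds shown, and "the series" means these compounds.

In a functional assay on B16-F0 cells (Mus musculus) for inhibition, read by CCK-8 assay, with a stated time of 48 h (a lower number here means a stronger inhibitor, a higher number a weaker inhibitor), three compounds sharing one core differ in a single group. Compound 1 `COc1cc(-c2ccnc3cc(-c4ccc(Cl)cc4)nn23)cc(OC)c1OC`, carrying 4-chlorophenyl, gives 4090 nM. The result for compound 2 `COc1cc(-c2ccnc3cc(-c4cccc(C#N)c4)nn23)cc(OC)c1OC`, carrying 3-cyanophenyl, is a limit of the assay and not a number: > 10000 nM. Compound 3 `COc1cc(-c2ccnc3cc(-c4ccc5ccn(C)c5c4)nn23)cc(OC)c1OC`, carrying 1-methyl-1H-indol-6-yl, gives 657 nM, the lowest number of the three.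

Compound 4 `COc1ccc(-c2cc3nccc(-c4cc(OC)c(OC)c(OC)c4)n3n2)cc1F` keeps the core of compound 3 but exchanges this group, with 3-fluoro-4-methoxyphenyl in place of 1-methyl-1H-indol-6-yl on an aromatic carbon. For the measured compounds named here, two measured steps bear most directly on this exchange. One is modest, a 6.2-fold lower number from compound 1 to compound 3 (0.79 log units; beyond the scatter), and the other is large, an at least 15-fold lower number from compound 2 to compound 3 (1.18 log units; beyond the scatter). Both run towards the indole, so leaving it for a substituted phenyl suggests a reversal, though the two phenyl compounds themselves differ, an at least 2.4-fold higher number from compound 1 to compound 2 (0.38 log units; beyond the scatter). A rise beyond the scatter is therefore expected, estimated as a 3.0-fold higher number from compound 3 to compound 4 (0.48 log units; beyond the scatter). For compound 4 the expected value is 2000 nM, with an estimated range of 600 nM to 7000 nM.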

Compound 4, half-maximal inhibitory concentration: 3950 nM
Beside the measured number, compound 4's estimate is 2.0-fold (0.30 log units) below it; the measured number falls inside the stated range.
By their numbers in this assay, from the lowest: compound 3; then compounds 4 and 1 (each within the scatter of the next). At a limit, above all of these: compound 2.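

In this assay, a 6.0-fold higher number from compound 3 to compound 4 (0.78 log units; beyond the scatter), so a second substituted phenyl also falls short of 1-methyl-1H-indol-6-yl, while exchanging 4-chlorophenyl for 3-fluoro-4-methoxyphenyl makes no distinction, a 1.0-fold lower number from compound 1 to compound 4 (0.02 log units; within the scatter). Among the phenyl groups shown, 3-cyanophenyl stays apart, an at least 2.5-fold lower number from compound 2 to compound 4 (0.40 log units; beyond the scatter). Compound 2 itself stands at a limit of the assay and not a number: the limit of > 10000 nM in this assay, at which 1 of the 4 values shown sits.

The compounds shown leave open whether the lower number of compound 3 goes with the fused two-ring group as such or with the methyl on its ring nitrogen, and an indol-6-yl group without that methyl or a naphthyl group would bear on this. They also leave open how a phenyl group carrying a hydroxyl or an amine would compare.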